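Amino acid side chain variation on a quinone series

A few compounds are considered here, and "the series" means these few. Any claim that something is new, unique, unknown or untested is made for them only; others in the source may bear on it.

Measured so far:
compound 1 `C=C1[C@H](C)CCC[C@]1(C)CC/C(C)=C/CC1=C(O)C(=O)C=C(N[C@@H](C(=O)O)C(C)C)C1=O`: 6.2 ug/mL
compound 2 `C=C1[C@H](C)CCC[C@]1(C)CC/C(C)=C/CC1=C(O)C(=O)C=C(N[C@H](CO)C(=O)O)C1=O`: > 10 ug/mL, a limit of the assay
compound 3 `C=C1[C@H](C)CCC[C@]1(C)CC/C(C)=C/CC1=C(O)C(=O)C=C(N[C@@H](CO)C(=O)O)C1=O`: > 10 ug/mL, a limit of the assay

Within the data shown here, in an ADME assay on KB cells (Homo sapiens) for cytotoxicity, with a stated time of 48 h (on this read-out lower numbers stand for stronger inhibition and higher numbers for weaker inhibition), compound 1 is the only member with a number. Compound 2 and compound 3 share the same atoms and bonds and differ only by the two compounds have the same atoms and bonds and differ only in configuration as drawn: 1 of 4 stereo elements differ; a stereocentre at a saturated chain carbon is drawn R in compound 2 and S in compound 3; the step that the two limits leave unreadable from compound 2 to compound 3 is unreadable because of the limit of > 10 ug/mL in this assay, at which 2 of the 3 values shown sit. The change isopropyl in place of hydroxymethyl on a saturated chain carbon bound to an amine nitrogen and a carbonyl carbon gave an at least 1.6-fold lower number from compound 2 to compound 1 (0.20 log units; that floor lies within the scatter), and in the other direction an at least 1.6-fold higher number from compound 1 to compound 3 (0.20 log units; that floor lies within the scatter).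

Compound 4 `C=C1[C@H](C)CCC[C@]1(C)CC/C(C)=C/CC1=C(O)C(=O)C=C(N[C@H](C(=O)O)C(C)C)C1=O` is not yet measured. It differs from compound 3 by isopropyl in place of hydroxymethyl on a saturated chain carbon bound to an amine nitrogen and a carbonyl carbon, the same change as that from compound 2 to compound 1, at the same place. From compound 3 a step of an at least 1.4-fold lower number from compound 3 to compound 4 (0.15 log units; that floor lies within the scatter) is expected, resting on an at least 1.6-fold lower number from compound 2 to compound 1 (0.20 log units; that floor lies within the scatter) and on (the fact that compounds 2 and 3 differ only in the configuration as drawn). Compound 4 is estimated at 7 ug/mL, between 3 ug/mL and 15 ug/mL.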

Compound 4, half-maximal inhibitory concentration: > 10 ug/mL
Compound 4: a limit, no number (the forecaster's own chance of this, stated with the estimate: 35%); middle value at least 1.4-fold (0.15 log units) away from the limit.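

Compound 4 gives > 10 ug/mL in this assay, a limit of the assay and not a number. The steps from compound 3 to compound 4 and from compound 2 to compound 4 cannot be read: the limit of > 10 ug/mL in this assay, at which 3 of the 4 values shown sit. The only readable step, an at least 1.6-fold higher number from compound 1 to compound 4 (0.20 log units; that floor lies within the scatter), joins the two isopropyl compounds, so the change from hydroxymethyl to isopropyl is neither shown to carry over to the other configuration nor shown to fail there: the fact that compounds 1 and 4 differ only in the configuration as drawn.

Open, as far as these compounds go, is how far compound 2, compound 3 and compound 4 lie past the limit. Also open, from the compounds shown here alone, is how a longer chain, an amine or a second carboxylic acid on a saturated chain carbon bound to an amine nitrogen and a carbonyl carbon would read in this assay.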